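From compound 2 to compound 3: one aromatic substituent

This account rests on a few compounds, and the source may have more. Where it says the series, first, only, none or still open, it means among the compounds named here.

In a functional assay on DU-145 cells (Homo sapiens) for inhibition (on this read-out higher numbers stand for weaker inhibition and lower numbers for stronger inhibition), compound 1 (`COc1ccc(Cl)cc1-c1cc(Nc2ccc(Cl)cc2)nc(N)n1`) gives 500 nM. Compound 2 (`CCOc1ccc(Br)cc1-c1cc(Nc2ccc(B(O)O)cc2)nc(N)n1`) gives 500 nM, level with compound 1 and within the scatter, so no order can be drawn between the two. Compound 3 (`CCOc1ccc(Br)cc1-c1cc(Nc2ccc(C#N)cc2)nc(N)n1`) differs from compound 2 in one place: a group of 2 heavy atoms (1 carbon, 1 nitrogen; no ring) in place of a group of 3 heavy atoms (1 boron, 2 oxygen; no ring), on an aromatic carbon. The cyano group sits on an aromatic carbon of a six-membered aromatic ring of carbon only, para to a large group. For the measured compounds named here, no measured pair differs in one place only, so the data give no direct measure of what such a change does. With compound 2 at 500 nM as the only anchor, no shift in either direction is expected beyond the scatter. The expected step is no change at the digits printed from compound 2 to compound 3 (within the scatter). For compound 3 the estimated value is 500 nM, with an expected range of 150 nM to 1700 nM.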

Compound 3, half-maximal inhibitory concentration: 400 nM
The estimate for compound 3 lay 1.3-fold (0.10 log units) above the measured number; measured number inside the range.
By their numbers in this assay, from the lowest: compounds 3, 1 and 2 (each within the scatter of the next).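

In this assay, cyano in place of the boron-and-oxygen group on this aromatic carbon gives a 1.3-fold lower number from compound 2 to compound 3 (0.10 log units; within the scatter) and so marks no difference between the two groups at this position. The pair also shows that the read-out stays within the scatter when the hydrogen-bond donors of the leaving group are lost and a triple bond enters, though this is a single exchange in a single background. No measurement shown here accounts for this result.

From the compounds shown here alone, whether an amine or a carboxylic acid on this aromatic carbon would hold the number remains open. Also open, going by these compounds, is whether the same exchange would read alike on the other substituents of compound 1, whose structure differs from compound 2 in more than one place.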